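Aryl ring variation on the shared core: outlook for compound 4

The source may report more compounds than this note shows. Statements on the series, on what has been measured and on what is new or still open speak of the compounds shown alone.

Compound 1 `CN1CCN(CCCOc2cccc3nc(Nc4ccc(Cl)c(F)c4)ccc23)CC1` gives 1950 nM in a functional assay on IGROV-1 cells (Homo sapiens) for inhibition, read by sulforhodamine B assay, with a stated time of 48 h; on this read-out lower numbers stand for stronger inhibition of growth and higher numbers for weaker inhibition of growth.
Compound 2 `CC(C)c1ccc(Nc2ccc3c(OCCCN4CCN(C)CC4)cccc3n2)cc1` gives 16100 nM in this assay.
Compound 3 `CN1CCN(CCCOc2cccc3nc(Nc4ccc(F)c(F)c4)ccc23)CC1` gives 5550 nM in this assay.

Compound 3 stands second highest of the three numbers. Its nearest step is a 2.8-fold higher number from compound 1 to compound 3 (0.45 log units; beyond the scatter); its furthest is a 2.9-fold lower number from compound 2 to compound 3 (0.46 log units; beyond the scatter). Both steps lie beyond the scatter, so compound 3 sits between the two others with a clear gap on either side.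

Compound 4 `CN1CCN(CCCOc2cccc3nc(Nc4cc(Cl)cc(Cl)c4)ccc23)CC1` differs from compound 3 by 3,5-dichlorophenyl in place of 3,4-difluorophenyl on a nitrogen on an aromatic ring. Among the compounds with values here, the one measured step that touches the same kind of exchange, fluoro against chloro on the aryl ring, is a 2.8-fold higher number from compound 1 to compound 3 (0.45 log units; beyond the scatter), which ran toward a higher number when chloro gave way to fluoro. Within the data shown here, compound 4 moves the other way, putting two chloro groups in place of two fluoro groups, with one of them moved on the ring; no measured pair covers that shift in position, so the direction is taken from the halogen exchange alone. A lower number in this assay is therefore expected, of a size near the measured halogen step, and the expected step is a 2.5-fold lower number from compound 3 to compound 4 (0.40 log units; beyond the scatter). The estimate for compound 4 is 2200 nM, with a range from 800 nM to 6500 nM.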

Compound 4, concentration for 50% growth inhibition: 1680 nM
The estimate for compound 4 lay 1.3-fold (0.12 log units) above the measured number, and the stated range covers the measured number.
By their numbers in this assay, from the lowest: compounds 4 and 1 (each within the scatter of the next); then compound 3; then compound 2.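

At this position, on a nitrogen on an aromatic ring, this assay shows a 3.3-fold lower number from compound 3 to compound 4 (0.52 log units; beyond the scatter) and a 9.6-fold lower number from compound 2 to compound 4 (0.98 log units; beyond the scatter), placing 3,5-dichlorophenyl at the low end of the set. With a 1.2-fold lower number from compound 1 to compound 4 (0.06 log units; within the scatter), 3,5-dichlorophenyl and 4-chloro-3-fluorophenyl cannot be told apart here, so the aryl change tolerates a different halogen pattern without a measurable shift. Both chloro-bearing compounds, compound 1 and compound 4, now stand below compound 3 and compound 2, with no compound of the four against this pattern, but nothing at hand accounts for it.

The step to compound 4 changes halogen and ring placement together, and the compounds shown do not separate the two. Also open, going by these compounds, is how 3,4-dichlorophenyl, or an aryl ring carrying trifluoromethyl or methoxy, would read at this nitrogen.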